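Imine in Place of Amide on the Shared Core

The source may hold more compounds than are shown below. What is called first, only, known or untested is meant among the compounds shown, and "the series" means these compounds.

Measured compounds:
compound 1 `N#CC1=C(N)N(c2ccc(S(N)(=O)=O)cc2)C2=C(C(=O)CCC2)C1c1ccc(Cl)cc1Cl`, 25 ug/mL
compound 2 `CC(Cl)CC(=O)NC1=C(C#N)C(c2ccc(Cl)cc2Cl)C2=C(CCCC2=O)N1c1ccc(S(N)(=O)=O)cc1`, 25 ug/mL
compound 3 `NC1=C(C(=O)O)C(c2ccc(Cl)cc2Cl)C2=C(CCCC2=O)N1c1ccc(S(N)(=O)=O)cc1`, > 100 ug/mL

In a functional assay on Ehrlich cells (Mus musculus) for cytotoxicity, read by trypan blue exclusion, with a stated time of 2 h (a lower number here means a stronger inhibitor, a higher number a weaker inhibitor), compound 1 gives 25 ug/mL. Compound 2 is the same core with an acyl group on the amine nitrogen, and in this assay compound 2 gives 25 ug/mL, level with compound 1 within the scatter, as the step of no change at the digits printed from compound 1 to compound 2 (within the scatter) shows. For compound 3 the assay reports only a limit, > 100 ug/mL; the step of an at least 4.0-fold higher number from compound 1 to compound 3 (0.60 log units; beyond the scatter) is therefore at least modest and goes toward weaker inhibition.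

Compound 4 `CN(C)c1ccc(/C=N/C2=C(C#N)C(c3ccc(Cl)cc3Cl)C3=C(CCCC3=O)N2c2ccc(S(N)(=O)=O)cc2)cc1` is not yet measured. It differs from compound 2 in one place: a group of 11 heavy atoms (9 carbon, 2 nitrogen; one six-membered aromatic ring of carbon only) in place of a group of 7 heavy atoms (4 carbon, 1 nitrogen, 1 oxygen, 1 chlorine; no ring), on a double-bonded ring carbon. Among the compounds with values here, of the two measured steps, only the one from compound 1 to compound 2 touches this same part of the core, and it produced no change beyond the scatter. The step to compound 3 concerns the cyano group, which compound 4 keeps, so it does not bear on this change. Within the data shown here, with one step of no change as the only guide, the expectation for compound 4 is a step of a 1.2-fold higher number from compound 2 to compound 4 (0.08 log units; within the scatter), that is, little movement. Compound 4 is therefore expected to give about 30 ug/mL in this assay, estimated between 10 ug/mL and 100 ug/mL.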

Compound 4, half-maximal inhibitory concentration: > 100 ug/mL
Compound 4: no number, only a limit; the forecaster's own chance of this, stated with the estimate: 15%; at least 3.3-fold (0.52 log units) between middle value and limit.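

At this position, on a double-bonded ring carbon next to the ring nitrogen, compound 2 had shown only that an acyl group on the amine leaves the result in this assay level with compound 1. The imine group carrying a six-membered aromatic ring shows that the position does not accept every change, with an at least 4.0-fold higher number from compound 2 to compound 4 (0.60 log units; beyond the scatter) and, measured against the free amine, an at least 4.0-fold higher number from compound 1 to compound 4 (0.60 log units; beyond the scatter). The result for compound 4 is a limit and not a number, so both steps give only a lower bound on the loss, and compound 4 shares that limit with one other compound: the limit of > 100 ug/mL in this assay, at which 2 of the 4 values shown sit.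

The change swaps several features at once, including the amide carbonyl, the amide hydrogen and the chlorine-bearing chain on one side and the aromatic ring and its dimethylamino group on the other, so the compounds shown cannot say which of these matters. A benzylamine or a benzamide at the same position would keep the aromatic ring along with a nitrogen-bound hydrogen, and a plain acetamide would show whether the chlorine-bearing chain plays any part.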